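The source may hold more compounds than are shown below. What is called first, only, known or untested is meant among the compounds shown, and "the series" means these compounds.

Measured in an ADME assay on HepG2 cells (Homo sapiens) for cytotoxicity, read by MTT assay, with a stated time of 72 h; on this read-out higher numbers stand for lower toxicity in this test and lower numbers for higher toxicity in this test:
- Compound 1 `O=[N+]([O-])c1c(CS(=O)(=O)c2ccccc2)nc2c(C#Cc3ccccc3F)cc(Cl)cn12`: > 3900 nM (a limit)
- Compound 2 `O=[N+]([O-])c1c(CS(=O)(=O)c2ccccc2)nc2c(C#Cc3cccnc3)cc(Cl)cn12`: > 3900 nM (a limit)
- Compound 3 `O=[N+]([O-])c1c(CS(=O)(=O)c2ccccc2)nc2c(C#CCO)cc(Cl)cn12`: 10100 nM

Within the data shown here, compound 3 holds the only true number in this assay, 10100 nM. The other two results are the limit of > 3900 nM in this assay, at which 2 of the 3 values shown sit.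

Compound 4 `CC(C)(O)C#Cc1cc(Cl)cn2c([N+](=O)[O-])c(CS(=O)(=O)c3ccccc3)nc12` differs from compound 3 in one place: 1-hydroxy-1-methylethyl in place of hydroxymethyl on a triple-bonded carbon. Here, 1-hydroxy-1-methylethyl stands in place of hydroxymethyl on a triple-bonded carbon.

Two measured steps change this same place: a step that the limit leaves unreadable from compound 1 to compound 3 and a step that the limit leaves unreadable from compound 2 to compound 3. Neither offers a size to go by. The expectation therefore stays with compound 3 at 10100 nM, with no step beyond the usual scatter expected in this assay. The estimated change is a 1.0-fold lower number from compound 3 to compound 4 (0.00 log units; within the scatter). For compound 4, the estimated value is 10000 nM, with an expected range of 4000 nM to 25000 nM.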

Compound 4, half-maximal cytotoxic concentration: > 62500 nM
Compound 4: a limit, no number; the forecaster's own chance of this, stated with the estimate: 35%; middle value at least 6.2-fold (0.79 log units) from the limit.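

Among these compounds, putting 1-hydroxy-1-methylethyl in place of hydroxymethyl on a triple-bonded carbon gives the first readable step at this place in this assay: an at least 6.1-fold higher number from compound 3 to compound 4 (0.79 log units; beyond the scatter). Going by these compounds, the result for compound 4 is a limit and not a number, so the full size of the step stays unknown: the limit of > 62500 nM in this assay, at which 1 of the 4 values shown sits. The steps linking compound 1 and compound 2 to compound 4 cannot be read.

On these data alone, whether a longer chain, or an amine in place of the hydroxyl, would give a number as high at this place remains open.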